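Second chloro on the 2-chlorophenyl group of compound 3

This account rests on a few compounds, and the source may have more. Where it says the series, first, only, none or still open, it means among the compounds named here.

Compound 3 `N#CC1=C(N)Oc2c(N)cc3nc4ccccc4nc3c2C12C(=O)N(Cc1cnnn1-c1ccccc1Cl)c1ccccc12` was measured in an ADME assay on HUVEC cells (Homo sapiens) for antiproliferative activity, read by MTT assay, with a stated time of 48 h; on this read-out lower numbers stand for stronger inhibition and higher numbers for weaker inhibition. In this assay compound 3 gives > 50000 nM, which is a limit of the assay and not a number. Compound 1 `CCOc1ccccc1-n1nncc1CN1C(=O)C2(C(C#N)=C(N)Oc3c2c2nc4ccccc4nc2c2ccccc32)c2ccccc21` also gives only a limit, > 50000 nM. Compound 2 `N#CC1=C(N)Oc2c(c3nc4ccccc4nc3c3ccccc23)C12C(=O)N(Cc1cnnn1-c1ccc(Cl)c(Cl)c1)c1ccccc12` likewise gives only a limit, > 50000 nM. All values shown thus sit at the limit of > 50000 nM in this assay, at which 3 of the 3 values shown sit, and compound 3 stands at this limit together with the other two; no ordering among them can be read.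

Compound 4 `N#CC1=C(N)Oc2c(N)cc3nc4ccccc4nc3c2C12C(=O)N(Cc1cnnn1-c1ccc(Cl)cc1Cl)c1ccccc12` differs from compound 3 by chloro in place of hydrogen on an aromatic carbon; read one bond further out, the change is 2-chlorophenyl to 2,4-dichlorophenyl.

Going by the values given here, the only measured step, a step that the two limits leave unreadable from compound 1 to compound 2, swaps the group on the aromatic nitrogen and is unreadable, since both of its values are limits. No measured step therefore bears readably on the change from compound 3 to compound 4, and no direction can be drawn from the numbers shown. The expectation for compound 4 in this assay is that it, too, sits at the limit, the expected step being a number no higher from compound 3 to compound 4 (the limit leaves the size open). Compound 4 is estimated at 50000 nM, between 20000 nM and 100000 nM.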

Compound 4, half-maximal inhibitory concentration: > 50000 nM
Compound 4: no number, only a limit; the forecaster's own chance of this, stated with the estimate: 85%; the middle value sits exactly at the limit.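

No step can be read between compound 3 and compound 4, as both give only a limit in this assay: the limit of > 50000 nM in this assay, at which 4 of the 4 values shown sit.

The compounds shown leave open whether any change to the group on the aromatic nitrogen gives a readable number in this assay.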